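The compounds below may be only part of what the source reports. "The series", "measured", "known", "first", "only" and "open" are said of these compounds alone.

Three compounds sharing one core have been run in a functional assay on CHO-K1 cells for agonist activity at Glucose-dependent insulinotropic receptor (Homo sapiens), read by a luciferase reporter, with a stated time of 5 h; on this read-out higher numbers stand for an effect only at larger amounts of compound and lower numbers for an effect already at smaller amounts. Compound 1 `CC(C)OC(=O)N1CCC(Oc2ncnc3c2CCN3c2ccc(S(C)(=O)=O)cc2F)CC1` gives 50.1 nM, compound 2 `CC(C)(C)OC(=O)N1CCC(Oc2ncnc3c2CCN3c2ccc(S(C)(=O)=O)cc2F)CC1` gives 20 nM, and compound 3 `COC(=O)N1CCC(Oc2ncnc3c2CCN3c2ccc(S(C)(=O)=O)cc2F)CC1` gives 316 nM, the highest number of the three, its steps to both others being beyond the scatter: a 6.3-fold higher number from compound 1 to compound 3 (0.80 log units; beyond the scatter) and a 16-fold higher number from compound 2 to compound 3 (1.20 log units; beyond the scatter). Compound 4 `CCOC(=O)N1CCC(Oc2ncnc3c2CCN3c2ccc(S(C)(=O)=O)cc2F)CC1` differs from compound 3 thus: methyl in place of hydrogen on a saturated chain carbon bound to an oxygen next to a carbonyl group. Those two steps bear directly, each putting methyl in place of a larger group on that oxygen and raising the number, as does a 2.5-fold lower number from compound 1 to compound 2 (0.40 log units; beyond the scatter), which is the same kind of change as here. A lower number is therefore expected for compound 4, estimated as a 2.4-fold lower number from compound 3 to compound 4 (0.39 log units; beyond the scatter). Compound 4 is estimated at 130 nM, with a range of 60 nM to 300 nM.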

Compound 4, half-maximal effective concentration: 251 nM
Estimate against measurement, compound 4: 1.9-fold (0.29 log units) below; the range from low to high includes it.
By their numbers in this assay, from the lowest: compound 2; then compound 1; then compounds 4 and 3 (each within the scatter of the next).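

In this assay, methyl in place of hydrogen on a saturated chain carbon bound to an oxygen next to a carbonyl group, taking methoxycarbonyl to ethoxycarbonyl, gives only a 1.3-fold lower number from compound 3 to compound 4 (0.10 log units; within the scatter). Ethyl remains well separated from isopropyl and tert-butyl on that oxygen, with a 5.0-fold higher number from compound 1 to compound 4 (0.70 log units; beyond the scatter) and a 13-fold higher number from compound 2 to compound 4 (1.10 log units; beyond the scatter). Even so, the effect of the added methyl cannot be told apart between its two settings: the same change on two cores in this assay, a 2.5-fold lower number (0.40 log units; beyond the scatter) from compound 1 to compound 2 and a 1.3-fold lower number (0.10 log units; within the scatter) from compound 3 to compound 4, 2.0-fold (0.30 log units) apart, within the scatter of two such steps.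

Going by these compounds, whether a longer chain such as n-propyl on that oxygen tracks ethyl or isopropyl remains open. On these data alone, the response to cyclopropyl there is also open.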